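From pyridin-4-yl to 5-fluoropyridin-3-yl in compound 4

The source may report more compounds than this note shows. Statements on the series, on what has been measured and on what is new or still open speak of the compounds shown alone.

Measured so far in an ADME assay (liver) for metabolic stability, with Liver microsome (Rattus norvegicus) as the target, using microsomes and NADPH, with a stated time of 30 min, tested at 1 uM; a lower number here means slower removal, a higher number faster removal of the compound

Compound 1 `Cn1cc(-c2cc(C(O)(C(F)(F)F)C(F)(F)F)cnc2N2CCN(S(=O)(=O)c3ccc(N)nc3)CC2)cn1` gives 44 mL.min-1.g-1
Compound 2 `CC(C)(C)n1cc(-c2cc(C(O)(C(F)(F)F)C(F)(F)F)cnc2N2CCN(S(=O)(=O)c3ccc(N)nc3)CC2)cn1` gives 459 mL.min-1.g-1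
Compound 3 `Nc1ccc(S(=O)(=O)N2CCN(c3ncc(C(O)(C(F)(F)F)C(F)(F)F)cc3-c3ccncc3)CC2)cn1` gives 31 mL.min-1.g-1

Compound 3 stands at the low end together with compound 1, while compound 2 lies far off. Compound 4 `Nc1ccc(S(=O)(=O)N2CCN(c3ncc(C(O)(C(F)(F)F)C(F)(F)F)cc3-c3cncc(F)c3)CC2)cn1` carries 5-fluoropyridin-3-yl in place of pyridin-4-yl on an aromatic carbon and has no tert-butyl. Going by the values given here, no measured step makes this exact change. Both large steps, (a 10-fold higher number from compound 1 to compound 2 (1.02 log units; beyond the scatter)) and (a 15-fold lower number from compound 2 to compound 3 (1.17 log units; beyond the scatter)), involve tert-butyl. Among the compounds with values here, the one exchange of aromatic groups without it, (a 1.4-fold lower number from compound 1 to compound 3 (0.15 log units; within the scatter)), stays small, so no step beyond the scatter is expected. The expected step is a 1.3-fold higher number from compound 3 to compound 4 (0.11 log units; within the scatter) in this assay. Compound 4 is estimated at 40 mL.min-1.g-1 with a range from 15 mL.min-1.g-1 to 100 mL.min-1.g-1 in this assay when measured.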

Compound 4, intrinsic clearance in microsomes: 19 mL.min-1.g-1
Compound 4: middle estimate off by 2.1-fold (0.32 log units), on the high side, within the range that was stated.
By their numbers in this assay, from the lowest: compounds 4, 3 and 1 (each within the scatter of the next, the first and the last beyond it); then compound 2.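

In this assay, the exchange of pyridin-4-yl for 5-fluoropyridin-3-yl (a 1.6-fold lower number from compound 3 to compound 4 (0.21 log units; within the scatter)) stays within the scatter, so this position carries either group without a separable difference. Unlike pyridin-4-yl, however, 5-fluoropyridin-3-yl stands apart from 1-methyl-1H-pyrazol-4-yl (a 2.3-fold lower number from compound 1 to compound 4 (0.36 log units; beyond the scatter)), a modest step, while the distance from 1-(tert-butyl)-1H-pyrazol-4-yl remains large (a 24-fold lower number from compound 2 to compound 4 (1.38 log units; beyond the scatter)). No supporting data bear on the reason for these steps. The compounds shown do not separate the fluorine from the place of the ring nitrogen. As far as these compounds go, what an unsubstituted pyridin-3-yl or a phenyl ring would give here stays open.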